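Chloro step from compound 2 to compound 3

This account rests on a few compounds, and the source may have more. Where it says the series, first, only, none or still open, it means among the compounds named here.

Two measured compounds anchor this series in a functional assay on P388 cells (Mus musculus) for antiproliferative activity, read by colorimetric assay and MTT assay; a higher number here means a weaker inhibitor, a lower number a stronger inhibitor. Compound 1 (`O=S(=O)(Nc1ccc(Cl)c2cc[nH]c12)c1ccc(Cl)cc1`) gives 4.6 ug/mL, and compound 2 (`O=[N+]([O-])c1ccc(S(=O)(=O)Nc2cccc3cc[nH]c23)cc1`) gives 8.2 ug/mL. These two values lie within the scatter of each other, so compound 2 stands level with compound 1 on the numbers available, and neither can be ranked.

Compound 3 (`O=[N+]([O-])c1ccc(S(=O)(=O)Nc2ccc(Cl)c3cc[nH]c23)cc1`) differs from compound 2 in one place, with chloro in place of hydrogen on an aromatic carbon, para to a large group (chloro in place of hydrogen on an aromatic carbon). For the measured compounds named here, no pair of measured compounds differs in one place only, so the data hold no measured step for this change. The expectation rests on the narrow span of the two values, with compound 1 at 4.6 ug/mL and compound 2 at 8.2 ug/mL. Only a small shift in this assay is expected, leaning towards a lower number and not beyond the scatter. The expected step is a 1.5-fold lower number from compound 2 to compound 3 (0.17 log units; within the scatter). For compound 3 the estimated value is 5.5 ug/mL, with an expected range of 2.2 ug/mL to 14 ug/mL.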

Compound 3, half-maximal inhibitory concentration: 3.3 ug/mL
Estimate against measurement, compound 3: 1.7-fold (0.22 log units) above, within the range that was stated.
By their numbers in this assay, from the lowest: compounds 3, 1 and 2 (each within the scatter of the next, the first and the last beyond it).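

In this assay, for the compounds shown here, chloro in place of hydrogen on an aromatic carbon, para to a large group, gives a 2.5-fold lower number from compound 2 to compound 3 (0.40 log units; beyond the scatter) and provides the first single-place step, a modest one that rests on one pair. With that chloro held in place, nitro in place of chloro on the other aromatic carbon gives a 1.4-fold lower number from compound 1 to compound 3 (0.14 log units; within the scatter) and leaves nitro and chloro at that site unseparated in this assay. No measurement in hand bears on the origin of either step.

From the compounds shown here alone, whether the chloro step carries over when chloro rather than nitro occupies the other site remains open, since the step has been read only with nitro in place and a single pair cannot establish a trend. Going by these compounds, how a methoxy group, an amine or a bromo group on the same aromatic carbon would compare with chloro also remains open, as does whether any such group would move the number beyond the scatter from compound 3.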